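The compounds below may be only part of what the source reports. "The series", "measured", "known", "first", "only" and "open" are said of these compounds alone.

Measured so far:
- compound 1, `COc1cc(-c2ncnn2-c2ccc([N+](=O)[O-])cc2)cc(OC)c1OC`: > 10000 nM
- compound 2, `COc1cc(-c2ncnn2-c2ccc(Cl)cc2)cc(OC)c1OC`: > 10000 nM
- compound 3, `COc1cc(-n2ncnc2-c2cccc([N+](=O)[O-])c2)cc(OC)c1OC`: > 10000 nM

All three were tested in a functional assay on MCF7 cells (Homo sapiens) for antiproliferative activity, read by MTT assay, with a stated time of 72 h; a lower number here means a stronger inhibitor, a higher number a weaker inhibitor. For compound 1 the result > 10000 nM is a limit of the assay, not a number. For compound 2 the result > 10000 nM is likewise a limit. For compound 3 the result > 10000 nM is a limit as well.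

Compound 2 comes from compound 1 by chloro in place of nitro on an aromatic carbon. The step that the two limits leave unreadable from compound 1 to compound 2 cannot be read, since both ends sit at the limit of > 10000 nM in this assay, at which 3 of the 3 values shown sit. Compound 3 has the same atoms as compound 1, joined differently; the difference between the two cores is not broken down here.

Compound 4, `COc1cc(-n2ncnc2-c2cccc(Cl)c2)cc(OC)c1OC`, has not yet been measured in this assay. It comes from compound 3 by chloro in place of nitro on an aromatic carbon. Going by the values given here, this is the same kind of change as the one from compound 1 to compound 2, but not the same: in compound 2 the chloro sits para to a large group, in compound 4 meta to a large group.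

The measured step of this kind gives no readable size, so the expectation leans on compound 3 and its > 10000 nM. The expected step is a step that the limit leaves unreadable from compound 3 to compound 4, with no reason in the data to look for a gain. Compound 4 is estimated at 15000 nM, between 3000 nM and 100000 nM, and most likely only a limit again.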

Compound 4, half-maximal inhibitory concentration: > 10000 nM
Compound 4: a limit, no number; the forecaster's own chance of this, stated with the estimate: 75%; the middle value lies beyond the limit too.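

In this assay compound 4 gives > 10000 nM, which is a limit of the assay and not a number. Compound 3 also ends at a limit, so no size can be read for chloro in place of nitro from compound 3 to compound 4: the limit of > 10000 nM in this assay, at which 4 of the 4 values shown sit.

The compounds shown leave open whether chloro and nitro differ at all in this assay, and what a true number for any of these compounds would be.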